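Working notes: 4-methoxyphenyl to 4-nitrophenyl on the shared core

The source may hold more compounds than are shown below. What is called first, only, known or untested is meant among the compounds shown, and "the series" means these compounds.

Three compounds that differ only in the aromatic group on the double-bonded chain have been measured in a functional assay on HeLa cells (Homo sapiens) for cytotoxicity, read by WST assay, with a stated time of 48 h; on this read-out lower numbers stand for stronger inhibition and higher numbers for weaker inhibition. Compound 1 `Oc1ccccc1/C=C/C[C@H]1C[C@@H]([C@@H](O)c2ccccc2)CO[C@@H]1c1ccccc1` gives 21800 nM, compound 2 `O[C@@H](c1ccccc1)[C@H]1CO[C@H](c2ccccc2)[C@@H](C/C=C/c2ccccn2)C1` gives 33800 nM, and compound 3 `COc1ccc(/C=C/C[C@H]2C[C@@H]([C@@H](O)c3ccccc3)CO[C@@H]2c2ccccc2)cc1` gives 8300 nM, the lowest of the three numbers. Compound 4 `O=[N+]([O-])c1ccc(/C=C/C[C@H]2C[C@@H]([C@@H](O)c3ccccc3)CO[C@@H]2c2ccccc2)cc1` keeps everything in compound 3 except one group: nitro in place of methoxy on an aromatic carbon, para to a large group (nitro in place of methoxy on an aromatic carbon). Going by the values given here, no measured compound carries nitro, so the evidence is indirect. The closest guides are changes of the same aromatic group: a 2.6-fold lower number from compound 1 to compound 3 (0.42 log units; beyond the scatter), and a 4.1-fold lower number from compound 2 to compound 3 (0.61 log units; beyond the scatter). Both are modest, while a 1.6-fold higher number from compound 1 to compound 2 (0.19 log units; within the scatter). With compound 3 at the low end of this small set, a small move towards higher numbers is expected, no larger than those modest steps, and it may not clear the scatter. The expected step in this assay is a 1.6-fold higher number from compound 3 to compound 4 (0.19 log units; within the scatter). For compound 4 the estimated value is 13000 nM, with an expected range of 4500 nM to 35000 nM.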

Compound 4, half-maximal inhibitory concentration: 12400 nM
Beside the measured number, compound 4's estimate is 1.0-fold (0.02 log units) above it; the range from low to high includes it.
By their numbers in this assay, from the lowest: compounds 3, 4, 1 and 2 (each within the scatter of the next, the first and the last beyond it).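

In this assay, nitro at this place, para to a large group, gives a value that cannot be told apart from methoxy (a 1.5-fold higher number from compound 3 to compound 4 (0.17 log units; within the scatter)), so the result separates neither group from the other. The 4-nitrophenyl compound keeps a gap beyond the scatter from the pyridin-2-yl compound (a 2.7-fold lower number from compound 2 to compound 4 (0.44 log units; beyond the scatter)) but not from the 2-hydroxyphenyl compound (a 1.8-fold lower number from compound 1 to compound 4 (0.25 log units; within the scatter)), whereas the 4-methoxyphenyl compound stood beyond the scatter from both. Nothing measured here accounts for how nitro and methoxy compare at this place.

Open, from the compounds shown here alone, is whether an amine or a carboxylic acid on this aromatic carbon would stay level with nitro and methoxy or give a higher number. Also open, going by these compounds, is whether a longer chain carrying the aromatic group would keep these values.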